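The compounds below may be only part of what the source reports. "The series", "measured", "known", "first", "only" and "open" are said of these compounds alone.

Measured so far in a functional assay on the whole organism for inhibition, with Rattus norvegicus as the target; on this read-out higher numbers stand for weaker inhibition and lower numbers for stronger inhibition:
compound 1, `COc1cc2c(cc1O)CCC(C(=O)NCc1ccccc1)O2`: 21700 nM
compound 2, `CCCNC(=O)C1CCc2cc(O)c(OC)cc2O1`: 42900 nM
compound 3, `COc1cc2c(cc1O)C(=O)CC(C(=O)NCc1ccccc1)O2`: 119000 nM

Compound 2 differs from compound 1 by ethyl in place of phenyl on a saturated chain carbon bound to an amide-type nitrogen. That step is a 2.0-fold higher number from compound 1 to compound 2 (0.30 log units; within the scatter). Compound 3 carries a different core; the difference between the core of compound 1 and the core of compound 3 is not broken down here. In this assay compound 3 gives the highest number of the three, beyond the scatter from both compound 1 and compound 2.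

Compound 4, `CCCNC(=O)C1CC(=O)c2cc(O)c(OC)cc2O1`, is not yet measured. It differs from compound 3 by ethyl in place of phenyl on a saturated chain carbon bound to an amide-type nitrogen: the same change as between compound 1 and compound 2, at the same place. Among the measured compounds shown here, only one measured pair shows this change, so the expectation rests on that single step. Given a 2.0-fold higher number from compound 1 to compound 2 (0.30 log units; within the scatter), the step from compound 3 to compound 4 is expected to be a 1.8-fold higher number from compound 3 to compound 4 (0.27 log units; within the scatter). Compound 4 is therefore estimated at 220000 nM, within a range from 100000 nM to 500000 nM.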

Compound 4, half-maximal inhibitory concentration: 80800 nM
For compound 4 the middle estimate is 2.7-fold (0.44 log units) above the measured one; the measured number lies below the stated range.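

In this assay the change of phenyl to ethyl on the saturated chain carbon bound to the amide-type nitrogen gives a 1.5-fold lower number from compound 3 to compound 4 (0.17 log units; within the scatter) on the core of compound 3. Set beside the same change on the core of compound 1, the size and direction of the step do not carry over from one core to the other: the same change on two cores in this assay, a 2.0-fold higher number (0.30 log units; within the scatter) from compound 1 to compound 2 and a 1.5-fold lower number (0.17 log units; within the scatter) from compound 3 to compound 4, 2.9-fold (0.46 log units) apart, beyond the scatter of two such steps. Each step alone stays within the scatter, so neither core by itself shows a clear effect of exchanging benzyl for propyl, and one pair per core cannot show why the two steps differ or how the change would behave on a further core.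

Only benzyl and propyl on the amide-type nitrogen can be compared here, on two cores. Open on both cores is whether a longer chain such as hexyl, or a chain ending in an amine or a carboxylic acid, would give a step beyond the scatter.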